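Ortho substituent swap on the benzylidene indanone series

This account rests on a few compounds, and the source may have more. Where it says the series, first, only, none or still open, it means among the compounds named here.

The series shares one core carrying a substituted benzylidene. Compound 1 `O=C1/C(=C/c2ccccc2Cl)Cc2ccccc21` bears a chloro group and in a functional assay on P388 cells (Mus musculus) for inhibition (on this read-out higher numbers stand for weaker inhibition and lower numbers for stronger inhibition), compound 1 gives 26500 nM. Compound 2 `O=C1/C(=C/c2ccccc2[N+](=O)[O-])Cc2ccccc21` carries a nitro group at the same position, and in this assay compound 2 gives 740 nM. Among the compounds with values here, compound 2 stands lowest of the two numbers; the only step measured so far is a 36-fold lower number from compound 1 to compound 2 (1.55 log units; beyond the scatter).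

Compound 3 `Cc1ccccc1/C=C1\Cc2ccccc2C1=O` is not yet measured. The change is methyl in place of nitro on an aromatic carbon. Within the data shown here, no measured step covers a methyl at this position. Among the measured compounds shown here, the one step that bears on it shows that the nitro group accompanies the low number of compound 2, so replacing it is expected to raise the number, but by an uncertain amount. The expected step is a 20-fold higher number from compound 2 to compound 3 (1.31 log units; beyond the scatter). The estimate for compound 3 in this assay is 15000 nM, with a range from 3000 nM to 60000 nM.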

Compound 3, half-maximal inhibitory concentration: 23900 nM
Compound 3: middle estimate off by 1.6-fold (0.20 log units), on the low side; the range from low to high includes it.
By their numbers in this assay, from the lowest: compound 2; then compounds 3 and 1 (each within the scatter of the next).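

In this assay, methyl in place of nitro gives a 32-fold higher number from compound 2 to compound 3 (1.51 log units; beyond the scatter) and thus the low number of compound 2 is lost when nitro leaves, now seen against a second group. Methyl in place of chloro gives a 1.1-fold lower number from compound 1 to compound 3 (0.04 log units; within the scatter) and thus methyl and chloro cannot be told apart at this position, leaving nitro as the only one of the three groups that stands apart. No measurement shown here accounts for this separation of nitro from the other two groups.

Still open, going by these compounds, is whether the low number belongs to nitro alone or would also appear with another group on this aromatic carbon, such as a nitrile, an amine or a carboxylic acid. A longer chain in place of methyl would show whether the number stays with those of compound 1 and compound 3.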